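The source may report more compounds than this note shows. Statements on the series, on what has been measured and on what is new or still open speak of the compounds shown alone.

Compound 1, `COc1ccc(C2=NO[C@]3(C2)C(=O)O[C@@H]2[C@H]3CC[C@H](C)[C@]3(O)C=CC(=O)[C@@]23C)cc1`, is one of two compounds in this set that carry the same steroid-like core with a small aromatic ring attached at one end. In a functional assay on PC-3 cells (Homo sapiens) for cytotoxicity, read by sulforhodamine B assay, with a stated time of 48 h (a lower number here means a stronger inhibitor, a higher number a weaker inhibitor), compound 1 gives 35000 nM. Compound 2, `C[C@H]1CC[C@@H]2[C@@H](OC(=O)[C@]23CC(c2ccccc2)=NO3)[C@]2(C)C(=O)C=C[C@@]12O`, keeps everything but has hydrogen in place of methoxy on an aromatic carbon; in this assay compound 2 gives 46000 nM. The step of a 1.3-fold higher number from compound 1 to compound 2 (0.12 log units; within the scatter) is too small to separate the two, so compound 2 sits alongside compound 1 rather than apart from it.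

Compound 3, `Cc1cccc(C2=NO[C@]3(C2)C(=O)O[C@@H]2[C@H]3CC[C@H](C)[C@]3(O)C=CC(=O)[C@@]23C)c1`, has not yet been measured. It differs from compound 2 by methyl in place of hydrogen on an aromatic carbon.

Going by the values given here, the only measured step, a 1.3-fold higher number from compound 1 to compound 2 (0.12 log units; within the scatter), also swapped a small group on that aromatic ring and left the number essentially unchanged. With nothing else to go on, the expectation for compound 3 is a step of a 1.1-fold lower number from compound 2 to compound 3 (0.04 log units; within the scatter), that is, no change beyond the scatter. Compound 3 is therefore estimated at 42000 nM in this assay, with a likely range from 15000 nM to 110000 nM.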

Compound 3, half-maximal inhibitory concentration: 66600 nM
Beside the measured number, compound 3's estimate is 1.6-fold (0.20 log units) below it; the range from low to high includes it.
By their numbers in this assay, from the lowest: compounds 1, 2 and 3 (each within the scatter of the next).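

Putting a methyl group on the ring, meta to a large group, gives a 1.4-fold higher number from compound 2 to compound 3 (0.16 log units; within the scatter) in this assay, so this second kind of small group, at a second place on the ring, also leaves the number within the scatter. Exchanging the whole substituent, 3-methylphenyl in place of 4-methoxyphenyl, gives a 1.9-fold higher number from compound 1 to compound 3 (0.28 log units; within the scatter), and even this change, which alters both the group and its place on the ring, stays within the scatter, so that compounds 1, 2 and 3 cannot be told apart in this assay. No separate measurement is available to explain this lack of separation.

On these data alone, these three compounds cover only hydrogen, methyl and methoxy on the ring, so it remains open whether an amine, a carboxylic acid or a longer chain there would move the number beyond the scatter. As far as these compounds go, it also remains open whether a methyl group at the position occupied by the methoxy in compound 1, or a replacement of the aromatic ring by a non-aromatic one, would leave the number just as it stands.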